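The source may hold more compounds than are shown below. What is called first, only, known or untested is meant among the compounds shown, and "the series" means these compounds.

Series notes. Compound 1 `NS(=O)(=O)c1cc(-c2nnc(CN3CCN(Cc4ccccc4)CC3)o2)c(Cl)cc1SCc1ccccc1` gives 26000 nM in a functional assay on HCT-116 cells (Homo sapiens) for cytotoxicity, read by MTT assay, with a stated time of 72 h; on this read-out lower numbers stand for stronger inhibition and higher numbers for weaker inhibition. Among the measured compounds shown here, compound 2 `NS(=O)(=O)c1cc(-c2nnc(CN3CCN(c4ccc(Cl)cc4)CC3)o2)c(Cl)cc1SCc1ccccc1` gives 78000 nM in this assay, and the only step so far is a 3.0-fold higher number from compound 1 to compound 2 (0.48 log units; beyond the scatter). Compound 3 `CCOC(=O)c1cn(Cc2nnc(-c3cc(S(N)(=O)=O)c(SCc4ccccc4)cc3Cl)o2)nn1` gives 108000 nM in this assay, the highest of the three numbers: the gap to compound 2 lies within the scatter, while the gap to compound 1 lies beyond it.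

Compound 4 `NS(=O)(=O)c1cc(-c2nnc(/C=C/c3cccc(Cl)c3)o2)c(Cl)cc1SCc1ccccc1` has not yet been measured. It differs from compound 3 at the shared core: 2-(3-chlorophenyl)ethenyl in place of (4-(ethoxycarbonyl)-1H-1,2,3-triazol-1-yl)methyl on an aromatic carbon. For the measured compounds named here, no measured step changes this position; the step from compound 1 to compound 2 alters a group on an amine nitrogen in a ring and bears only loosely on the present change, showing that a modest shift can follow a swap of an aryl group. The entering group brings no hydrogen-bond acceptors where the leaving group carried five.

Going by the values given here, with no direct precedent, the expectation for compound 4 is a number near that of compound 3, at most a modest move, and the estimated step is a 1.8-fold lower number from compound 3 to compound 4 (0.26 log units; within the scatter), within the scatter. Compound 4 is expected to give about 60000 nM in this assay, with a plausible range from 15000 nM to 200000 nM.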

Compound 4, half-maximal inhibitory concentration: 12000 nM
The estimate for compound 4 lay 5.0-fold (0.70 log units) above the measured number; the whole stated range lies above it.
By their numbers in this assay, from the lowest: compound 4; then compound 1; then compounds 2 and 3 (each within the scatter of the next).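

Working notes on the core position. In this assay, the group on the aromatic carbon of the five-membered aromatic ring with 2 nitrogen and 1 oxygen is shown for the first time to shift the number on its own, with a 9.0-fold lower number from compound 3 to compound 4 (0.95 log units; beyond the scatter) beyond the scatter, whereas the earlier step of a 3.0-fold higher number from compound 1 to compound 2 (0.48 log units; beyond the scatter) concerned a group on an amine nitrogen in a ring. The change has several parts: a carbon-only six-membered aromatic ring and a chlorine enter, a five-membered aromatic ring with 3 hetero atoms and an ethyl ester leave, and hydrogen-bond acceptors in the group go from 5 to 0, so this single step cannot assign the shift to any one of these features. No measurement bearing on the origin of this shift is available.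

The compounds shown leave open how much of the step belongs to the chlorine, to the ethenyl link or to the carbon-only aromatic ring. Also open, from the compounds shown here alone, is how a saturated two-carbon link, or a methoxy group or a carboxylic acid on that ring, would read in this assay at this same position.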